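The source may hold more compounds than are shown below. What is called first, only, known or untested is meant among the compounds shown, and "the series" means these compounds.

Measured so far in an ADME assay on microsomes from liver (Mus musculus) for metabolic stability, with a stated time of 10 min; a higher number here means that more of the compound is left, a lower number that less of the compound is left:
- compound 1 `CS(=O)(=O)N1CCC(C(=O)N2CC[C@](c3ccc(C(F)(C(F)(F)F)C(F)(F)F)cc3)(S(=O)(=O)c3ccc(F)cc3)C2)CC1`: 69%
- compound 2 `O=C(O)[C@H]1CC[C@H](C(=O)N2CC[C@](c3ccc(C(F)(C(F)(F)F)C(F)(F)F)cc3)(S(=O)(=O)c3ccccc3)C2)CC1`: 96%
- compound 3 `CCc1ccc(S(=O)(=O)[C@@]2(c3ccc(C(F)(C(F)(F)F)C(F)(F)F)cc3)CCN(C(=O)[C@H]3CC[C@H](C(=O)O)CC3)C2)cc1`: 100%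

Compound 3, at 100%, lies within the scatter of compound 2 and beyond the scatter of compound 1, and so sits in the upper group of the three numbers. Compound 4 `COc1ccc(S(=O)(=O)[C@@]2(c3ccc(C(F)(C(F)(F)F)C(F)(F)F)cc3)CCN(C(=O)[C@H]3CC[C@H](C(=O)O)CC3)C2)cc1` carries methoxy in place of ethyl on an aromatic carbon, para to a large group: methoxy in place of ethyl on an aromatic carbon. Among the compounds with values here, one measured step bears on this change: a number 4 percentage points higher from compound 2 to compound 3 (within the scatter). Within the data shown here, that step lies within the scatter, but it brings in ethyl, and no measured step brings in methoxy. No step beyond the scatter is therefore expected in this assay, though a small drop would not surprise. The estimated step is a number 6 percentage points lower from compound 3 to compound 4 (within the scatter). For compound 4 the expected value is 94%, with an estimated range of 82% to 100%.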

Compound 4, percent of the compound remaining: 98%
Beside the measured number, compound 4's estimate is 4 percentage points below it; measured number inside the range.
By their numbers in this assay, from the lowest: compound 1; then compounds 2, 4 and 3 (each within the scatter of the next).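

Within the data shown here, at the aromatic carbon para to a large group, this assay now covers a group with a hydrogen-bond acceptor, which the earlier compounds did not show there: methoxy in place of ethyl gives a number 2 percentage points lower from compound 3 to compound 4 (within the scatter) and methoxy in place of hydrogen gives a number 2 percentage points higher from compound 2 to compound 4 (within the scatter) at this position. Hydrogen, ethyl and methoxy thus stay within the scatter of one another. Nothing shown gives a reason for this result. On these data alone, whether an amine or a nitrile at this position would stay within the scatter remains open. So does whether methoxy would behave alike without the carboxylic acid of compound 4.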